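Methoxy to hydroxy on the dimethylamino-bearing analogue

The compounds below may be only part of what the source reports. "The series", "measured", "known", "first", "only" and "open" are said of these compounds alone.

Measured so far in a functional assay on NCI/ADR-RES cells (Homo sapiens) for inhibition, read by sulforhodamine B assay, with a stated time of 48 h; on this read-out lower numbers stand for higher toxicity in this test and higher numbers for lower toxicity in this test:
compound 1 `Cc1cc(O)cc(-c2nn(CC#N)cc2-c2ccnc(-c3ccc(Oc4ccccc4)cc3)c2)c1`: 15800 nM
compound 2 `COc1cc(C)cc(-c2nn(CC#N)cc2-c2ccnc(-c3ccc(N(C)C)cc3)c2)c1`: limit, > 100000 nM

Compound 1 gives 15800 nM in this assay. Compound 2 returns no number in this assay, only > 100000 nM, a limit of the measurement. Of the two results, compound 2 is the one sitting at the limit of > 100000 nM in this assay, at which 1 of the 2 values shown sits. Among the measured compounds shown here, compound 1 and compound 2 differ in two places, so the two values show only that compound 1 is measurable and compound 2 is not.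

Compound 3 `Cc1cc(O)cc(-c2nn(CC#N)cc2-c2ccnc(-c3ccc(N(C)C)cc3)c2)c1` follows from compound 2 by hydrogen in place of methyl on an oxygen on an aromatic ring. For the measured compounds named here, no step between measured compounds with this change exists here, so its size is unknown. Since compound 2 stands at a limit, the true value of compound 2 is itself open; a change of the expected size an at least 1.4-fold lower number from compound 2 to compound 3 (0.15 log units; that floor lies within the scatter) from compound 2 to compound 3 is assumed, likely small and toward higher toxicity in this test. Compound 3 is estimated at 70000 nM, between 15000 nM and 300000 nM, with a real chance that this assay again reports only a limit.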

Compound 3, concentration lethal to 50% of the cells: > 100000 nM
Compound 3: a limit, no number (the forecaster's own chance of this, stated with the estimate: 50%); at least 1.4-fold (0.15 log units) between middle value and limit.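

In this assay, as far as these compounds go, phenoxy and dimethylamino can now be compared on the same hydroxy-bearing core, and dimethylamino in place of phenoxy on an aromatic carbon gives an at least 6.3-fold higher number from compound 1 to compound 3 (0.80 log units; beyond the scatter); the end of this step is a limit of the measurement, so its true size stays open. Among the three compounds, a measured number appears only with phenoxy, and hydroxy in place of methoxy does not bring the dimethylamino analogue to a number. The methoxy to hydroxy step cannot be read, because compound 2 and compound 3 both stand at a limit: the limit of > 100000 nM in this assay, at which 2 of the 3 values shown sit.

Open, from the compounds shown here alone, is whether methoxy to hydroxy alters the read-out on the phenoxy-bearing compound 1, whose value is a number rather than a limit. Also open, going by these compounds, is how a morpholine or a benzyloxy group would read in place of phenoxy.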